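The compounds below may be only part of what the source reports. "The series", "measured", "known", "first", "only" and "open" are said of these compounds alone.

In a functional assay on P388 cells (Mus musculus) for antiproliferative activity, with a stated time of 72 h (on this read-out higher numbers stand for an effect only at larger amounts of compound and lower numbers for an effect already at smaller amounts), compound 3 (`Cc1cn([C@@H]2O[C@H](CO)[C@@H](CO)[C@@H]2O)c(=O)[nH]c1=O`) gives > 100 uM as a limit of the assay, not a number. Compound 1 (`Cc1cn([C@@H]2O[C@H](CO)[C@@H](CN=[N+]=[N-])[C@@H]2O)c(=O)[nH]c1=O`) gives > 100 uM as a limit too. Compound 2 (`Cc1cn([C@@H]2O[C@H](CO)[C@@H](CN)[C@H]2O)c(=O)[nH]c1=O`) gives > 100 uM as a limit too. All three therefore sit together (the limit of > 100 uM in this assay, at which 3 of the 3 values shown sit) with no number among them. Set against compound 3, compound 4 (`Cc1cn([C@@H]2O[C@H](CO)[C@@H](CN)[C@@H]2O)c(=O)[nH]c1=O`) carries amino in place of hydroxy on a saturated chain carbon bound to a saturated ring carbon and nothing else changes. For the measured compounds named here, the only measured step that bears on this is hydroxy in place of azido at that same place (a step that the two limits leave unreadable from compound 1 to compound 3) and its size cannot be read. No step beyond the scatter is therefore expected in either direction in this assay and another limit is the likeliest report. The expected step (a number no higher from compound 3 to compound 4 (the limit leaves the size open)) is thus small. For compound 4 the estimated value is 100 uM with an expected range from 40 uM to 250 uM on this read-out.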

Compound 4, concentration for half-maximal effect: > 100 uM
Compound 4 gave a limit, no number; the forecaster's own chance of this, stated with the estimate: 85%; the middle value sits exactly at the limit.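

In this assay compound 4 gives > 100 uM, a limit, so its steps to compound 1, compound 2 and compound 3 cannot be read. The compounds shown leave open whether azido, hydroxy, amino or the configuration as drawn makes any difference to the activity in this assay.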